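The source may report more compounds than this note shows. Statements on the series, on what has been measured and on what is new or still open speak of the compounds shown alone.

Compound 1 `CCC(O)Cc1cn(CC(=O)NCc2ccccc2)nn1` was tested in an ADME assay on cells (spleen, Mus musculus, strain C57BL/6) for inhibition, read by flow cytometry and propidium iodide staining, with a stated time of 24 h, at 37 degrees C (a lower number here means that less compound is needed, a higher number that more compound is needed for the effect), where compound 1 gives 630 uM; this is the only number shown, and compound 2 `Cc1ccc(-c2cn(CC(=O)NCc3ccccc3)nn2)cc1` was reported in this assay as "non-toxic" (no number reported). Compound 3 `COc1ccc(-c2cn(CC(=O)NCc3ccccc3)nn2)cc1` has not yet been measured. It differs from compound 1 in one place: 4-methoxyphenyl in place of 2-hydroxybutyl on an aromatic carbon. For the measured compounds named here, no measured pair shows how large such a change is in this assay. Because compound 2 gives "non-toxic" (no number reported) and also carries a six-membered aromatic ring of carbon only, a modest upward step is expected, a 1.4-fold higher number from compound 1 to compound 3 (0.15 log units; within the scatter). Compound 3 is expected to give 900 uM, between 300 uM and 3000 uM.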

Compound 3, concentration for half-maximal effect: "non-toxic" (no number reported)
Compound 3: no number reported; the estimate stays without a comparison.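

For the compounds shown here, compound 3, like compound 2, is reported without a number, so no step from compound 1 to compound 3 can be read. Nothing shown here offers an explanation. Left open is whether 4-methoxyphenyl in place of 2-hydroxybutyl shifts the concentration needed, and by how much.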